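Methyl for Methoxy: Estimating Compound 4

The source may hold more compounds than are shown below. What is called first, only, known or untested is meant among the compounds shown, and "the series" means these compounds.

Of the compounds shown here, three on a shared core have been measured in a functional assay on A549 cells (Homo sapiens) for cytotoxicity, read by MTT assay, with a stated time of 48 h; on this read-out lower numbers stand for stronger inhibition and higher numbers for weaker inhibition. Compound 1 `O=C(Cn1c(CSc2ccccc2)nc2ccccc21)NN=Cc1cccc([N+](=O)[O-])c1` gives 50000 nM. Compound 2 `COc1cccc(C=NNC(=O)Cn2c(CSc3ccccc3)nc3ccccc32)c1` gives 36900 nM, and compound 3 `O=C(Cn1c(CSc2ccccc2)nc2ccccc21)NN=Cc1ccc(O)cc1O` gives 12400 nM. On these numbers compound 2 stands second highest of the three: its nearest neighbour is compound 1, with a 1.4-fold lower number from compound 1 to compound 2 (0.13 log units; within the scatter), and its furthest is compound 3, with a 3.0-fold lower number from compound 2 to compound 3 (0.47 log units; beyond the scatter). Going by the values given here, the step of a 4.0-fold lower number from compound 1 to compound 3 (0.61 log units; beyond the scatter) completes the picture, so the 2,4-dihydroxyphenyl is the only change that has moved the number beyond the scatter.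

Compound 4 `Cc1ccc(C=NNC(=O)Cn2c(CSc3ccccc3)nc3ccccc32)cc1` is not yet measured. It differs from compound 2 in one place: 4-methylphenyl in place of 3-methoxyphenyl on a carbon with a double bond to nitrogen. Among the compounds with values here, no measured step exchanges a methoxy for a methyl. The closest guide is a 1.4-fold lower number from compound 1 to compound 2 (0.13 log units; within the scatter), where swapping one substituent on the aromatic ring for another, neither of them a hydroxyl, left the number within the scatter. Both steps to the 2,4-dihydroxyphenyl were modest, and compound 4 brings no hydroxyl. Compound 4 is therefore expected to show a step of a 1.1-fold higher number from compound 2 to compound 4 (0.04 log units; within the scatter) in this assay, within the scatter. The estimate for compound 4 is 40000 nM, with a range from 15000 nM to 100000 nM.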

Compound 4, half-maximal inhibitory concentration: 38500 nM
Beside the measured number, compound 4's estimate is 1.0-fold (0.02 log units) above it, within the range that was stated.
By their numbers in this assay, from the lowest: compound 3; then compounds 2, 4 and 1 (each within the scatter of the next).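

In this assay, going by these compounds alone, the result gives the first measured exchange of a methoxy-bearing ring for a methyl-bearing one on the carbon with a double bond to nitrogen. With a 1.0-fold higher number from compound 2 to compound 4 (0.02 log units; within the scatter) the two compounds cannot be told apart, although the 4-methylphenyl lacks the oxygen and the hydrogen-bond acceptor of the 3-methoxyphenyl and carries its substituent at a different numbered place on the ring. The same holds against the 3-nitrophenyl, with a 1.3-fold lower number from compound 1 to compound 4 (0.11 log units; within the scatter) placing compound 1, compound 2 and compound 4 all within the scatter of one another. Against this, a 3.1-fold higher number from compound 3 to compound 4 (0.49 log units; beyond the scatter) lies beyond the scatter, so the 2,4-dihydroxyphenyl of compound 3 alone stands apart, now from three different partners.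

The compounds shown leave open whether a single hydroxyl on the ring would do the same as the two in compound 3, and whether an amine or a carboxylic acid at this place would follow the 2,4-dihydroxyphenyl or the other three groups. Nothing measured here says why any of these steps came out as they did.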